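This account rests on a few compounds, and the source may have more. Where it says the series, first, only, none or still open, it means among the compounds named here.

Measured in a functional assay on MCF7 cells (Homo sapiens) for inhibition, read by radiometric assay and XTT assay; a higher number here means a weaker inhibitor, a lower number a stronger inhibitor:
- compound 1 `CCCCCC[C@@]1(C)SC(=O)C=C1OCC(=O)OCC`: 39.6 ug/mL
- compound 2 `CCCCCCCC[C@@]1(C)SC(=O)C=C1OCC(=O)OCC`: 35.3 ug/mL
- compound 3 `C=CCC1(CC=C)C(=O)S[C@](C)(CCCCCCCC)C1=O`: 40.5 ug/mL

Compound 1, at 39.6 ug/mL, sits in a tight group, with its gaps to compound 2 and compound 3 both within the usual scatter. Compound 4 `CCCCCC[C@@]1(C)SC(=O)C=C1OCC(=O)NCCCBr`, not yet measured, keeps the core of compound 1 and differs at one place: (3-bromopropyl)amino in place of ethoxy on a carbonyl carbon.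

Among the compounds with values here, the only measured step, a 1.1-fold lower number from compound 1 to compound 2 (0.05 log units; within the scatter), is a small one on the chain and leaves the ethoxy untouched, so it bears only indirectly on this swap. Compound 3, at 40.5 ug/mL, also lacks the ethoxy, but it differs from compound 1 in more than one place and gives no clean comparison. Within the data shown here, no measured step changes the group on this carbonyl carbon. No step beyond the scatter is therefore expected in this assay, and no direction can be named, although the uncertainty is wide.

The expected step is a 1.1-fold lower number from compound 1 to compound 4 (0.05 log units; within the scatter). The estimated value for compound 4 is 35 ug/mL, with an expected range of 15 ug/mL to 70 ug/mL.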

Compound 4, half-maximal inhibitory concentration: 21 ug/mL
Compound 4: the middle estimate sits 1.7-fold (0.22 log units) above what was measured, within the range that was stated.
By their numbers in this assay, from the lowest: compounds 4, 2, 1 and 3 (each within the scatter of the next).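

In this assay, within the data shown here, this is the first look at a change on this carbonyl carbon: (3-bromopropyl)amino in place of ethoxy gives a 1.9-fold lower number from compound 1 to compound 4 (0.28 log units; within the scatter) and so shows no clear gain or loss. Ethoxycarbonyl can therefore become (3-bromopropyl)carbamoyl, bringing in a nitrogen, an amide hydrogen, a bromine and a larger group, without a step beyond the scatter in this assay. No supporting measurement is available to explain this result.

The compounds shown do not separate the part played by the amide nitrogen from that of the bromine, which a plain propylamino group on the same carbonyl carbon would address. Also open, on these data alone, is how a carboxylic acid would behave at this place, and whether the same swap gives a similar result on the longer chain of compound 2.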